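The source may report more compounds than this note shows. Statements on the series, on what has been measured and on what is new or still open speak of the compounds shown alone.

Series notes. Compound 1 `COc1cc(-c2nc3ccccc3s2)ccc1OCC(=O)NNC(=O)CN[C@@H](CS)C(=O)O` is the reference point of the set; in a functional assay on HepG2 cells (Homo sapiens) for inhibition, read by MTT assay, with a stated time of 3 days (a higher number here means a weaker inhibitor, a lower number a stronger inhibitor), compound 1 gives 3120 nM. Compound 2 `COc1cc(-c2nc3ccccc3s2)ccc1OCC(=O)NNC(=O)CN(C(C)=O)[C@@H](CS)C(=O)O` carries acetyl in place of hydrogen on an amine nitrogen, and in this assay compound 2 gives 3420 nM; the step is a 1.1-fold higher number from compound 1 to compound 2 (0.04 log units; within the scatter). Compound 3 `CCOC(=O)[C@H](CS)NCC(=O)NNC(=O)COc1ccc(-c2nc3ccccc3s2)cc1OC` differs from compound 1 in its core by ethyl in place of hydrogen on an oxygen next to a carbonyl group; in this assay compound 3 gives 3760 nM, a step of a 1.2-fold higher number from compound 1 to compound 3 (0.08 log units; within the scatter). Compound 2 set against compound 3 reads a 1.1-fold higher number from compound 2 to compound 3 (0.04 log units; within the scatter). All three numbers sit close together, and none of the three compounds can be set apart from the others on this read-out.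

Compound 4 `CCOC(=O)[C@H](CS)N(CC(=O)NNC(=O)COc1ccc(-c2nc3ccccc3s2)cc1OC)C(C)=O` has not been measured. For the measured compounds named here, it carries acetyl in place of hydrogen on an amine nitrogen, the same change as the one from compound 1 to compound 2, here made on the core of compound 3, with the place of the change described in identical terms. The step from compound 3 to compound 4 in this assay is expected to be a 1.1-fold higher number from compound 3 to compound 4 (0.04 log units; within the scatter), beside the measured 1.1-fold higher number from compound 1 to compound 2 (0.04 log units; within the scatter); the expectation rests on that single pair and therefore carries the width of one precedent only. Compound 4 is accordingly estimated at 4100 nM, within a range from 2500 nM to 7000 nM.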

Compound 4, half-maximal inhibitory concentration: 3010 nM
Compound 4: middle estimate off by 1.4-fold (0.13 log units), on the high side; the range from low to high includes it.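

In this assay, acetyl in place of hydrogen on the amine nitrogen gives a 1.2-fold lower number from compound 3 to compound 4 (0.10 log units; within the scatter), and this step does not differ from its earlier counterpart: the same change on two cores in this assay, a 1.1-fold higher number (0.04 log units; within the scatter) from compound 1 to compound 2 and a 1.2-fold lower number (0.10 log units; within the scatter) from compound 3 to compound 4, 1.4-fold (0.14 log units) apart, within the scatter of two such steps
The ethyl change reads the same way, at a 1.1-fold lower number from compound 2 to compound 4 (0.06 log units; within the scatter), and again the two steps do not differ: the same change on two cores in this assay, a 1.2-fold higher number (0.08 log units; within the scatter) from compound 1 to compound 3 and a 1.1-fold lower number (0.06 log units; within the scatter) from compound 2 to compound 4, 1.4-fold (0.14 log units) apart, within the scatter of two such steps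
With both changes together, the result is a 1.0-fold lower number from compound 1 to compound 4 (0.02 log units; within the scatter), so on these two cores neither change moves the number beyond the scatter; this shows agreement among small steps, not a transferable effect of a definite size or direction, and it rests on a single pair of steps for each change.

As far as these compounds go, it remains open whether a larger group on the same amine nitrogen, such as benzoyl or a longer acyl chain, would produce a step beyond the scatter. The same question applies to a hydroxyl group in place of the sulfanyl group, or to a primary amide in place of the ester.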